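The source may report more compounds than this note shows. Statements on the series, on what has been measured and on what is new or still open speak of the compounds shown alone.

Compound 2 `O=C(/C=C/c1ccc([N+](=O)[O-])o1)c1ccc(C2CCCCC2)cc1` is known in an ADME assay on Vero cells (Chlorocebus sabaeus) for cytotoxicity, read by resazurin assay, with a stated time of 72 h (on this read-out lower numbers stand for higher toxicity in this test and higher numbers for lower toxicity in this test), only as a limit: in this assay compound 2 gives > 100000 nM. Compound 3 `O=C(/C=C/c1ccc([N+](=O)[O-])o1)c1ccc(-c2ccccc2)cc1` likewise reaches a limit, giving > 100000 nM in this assay. The step that the two limits leave unreadable from compound 2 to compound 3 therefore cannot be sized, because the limit of > 100000 nM in this assay, at which 2 of the 3 values shown sit, hides both ends. Compound 1 `Cc1cccc(C(=O)/C=C/c2ccc([N+](=O)[O-])o2)c1` gives a number, 55100 nM in this assay. Compound 4 `O=C(/C=C/c1ccc([N+](=O)[O-])o1)c1ccc(Br)cc1` differs from compound 2 by bromo in place of cyclohexyl on an aromatic carbon. Within the data shown here, no measured step introduces bromo, and the one step at this position, from compound 2 to compound 3, is unreadable, so no direction can be taken from the data. Compound 4 is expected to sit near the limit, at about 80000 nM, between 30000 nM and 200000 nM. The step of an at least 1.2-fold lower number from compound 2 to compound 4 (0.09 log units; that floor lies within the scatter) is thus expected to stay within the scatter.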

Compound 4, half-maximal cytotoxic concentration: > 100000 nM
Compound 4 was reported as a limit; the forecaster's own chance of this, stated with the estimate: 50%; middle value at least 1.2-fold (0.09 log units) away from the limit.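

No new step can be read among compound 2, compound 3 and compound 4 in this assay, because each of them stops at a limit: the limit of > 100000 nM in this assay, at which 3 of the 4 values shown sit.

The compounds shown leave open how bromo, phenyl and cyclohexyl compare at this position.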